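The compounds below may be only part of what the source reports. "The series", "measured", "known", "first", "only" and "open" are said of these compounds alone.

In a functional assay on LOX IMVI cells (Homo sapiens) for cytotoxicity, read by MTT assay, with a stated time of 24 h (on this read-out lower numbers stand for stronger inhibition and higher numbers for weaker inhibition), compound 1 `COc1cc(-c2nc(-c3ccccc3)[nH]c2-c2ccnc(NCCCNS(=O)(=O)c3ccccc3)n2)ccc1F` gives 4520 nM and compound 2 `COc1ccc(S(=O)(=O)NCCCNc2nccc(-c3[nH]c(-c4ccccc4)nc3-c3ccc(F)c(OC)c3)n2)cc1` gives 6130 nM while compound 3 `COc1cc(-c2nc(-c3ccccc3)[nH]c2-c2ccnc(NCCCNS(=O)(=O)c3ccccc3)n2)ccc1Cl` gives 7470 nM in the same test. Compound 3 therefore stands level with the other two, all within the usual scatter. The change to compound 4 `COc1cc(-c2nc(-c3ccccc3)[nH]c2-c2ccnc(NCCCNS(=O)(=O)c3ccc(Br)cc3)n2)ccc1Cl` is bromo in place of hydrogen on an aromatic carbon on a six-membered aromatic ring of carbon only, para to a large group. Going by the values given here, no bromo compound has been measured yet, but two steps bear on this one. Methoxy in place of hydrogen on that same ring gave a 1.4-fold higher number from compound 1 to compound 2 (0.13 log units; within the scatter) and chloro in place of fluoro gave a 1.7-fold higher number from compound 1 to compound 3 (0.22 log units; within the scatter) on another ring. The expected step of a 1.1-fold lower number from compound 3 to compound 4 (0.03 log units; within the scatter) in this assay would likewise stay within the scatter. For compound 4 the estimated value is 7000 nM (expected range 3200 nM to 15000 nM).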

Compound 4, half-maximal inhibitory concentration: 23700 nM
Compound 4: middle estimate off by 3.4-fold (0.53 log units), on the low side; the measured number lies above the stated range.
By their numbers in this assay, from the lowest: compounds 1, 2 and 3 (each within the scatter of the next); then compound 4.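

Bromo in place of hydrogen on the phenylsulfonyl ring, para to a large group, gives a 3.2-fold higher number from compound 3 to compound 4 (0.50 log units; beyond the scatter) in this assay, the first step here that lies beyond the scatter and points to weaker inhibition. This position therefore responds to at least one substituent, although methoxy on the same ring gave only a 1.4-fold higher number from compound 1 to compound 2 (0.13 log units; within the scatter). Nothing measured here gives a cause for this step.

Open, from the compounds shown here alone, is whether an amine or a carboxylic acid at this place would also raise the number. Also open, going by these compounds, is whether bromo would give a similar step with fluoro in place of chloro on the other ring.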